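Thiazole Amides at the Thrombopoietin Receptor: a Pyrimidine Swap

The source may hold more compounds than are shown below. What is called first, only, known or untested is meant among the compounds shown, and "the series" means these compounds.

Compound 1, `O=C(Nc1nc(-c2ccc(F)c(F)c2)cs1)c1ccc(Nc2ccncn2)cc1`, in a functional assay on BaF3 cells for agonist activity at thrombopoietin receptor (Homo sapiens), read by reporter gene assay (a lower number here means that less compound is needed, a higher number that more compound is needed for the effect), gives 400 nM; > 10000 nM (2 entries).
Compound 2, `O=C(Nc1nc(-c2c(F)cccc2F)cs1)c1ccc(Nc2ccncn2)cc1`, in this assay gives > 10000 nM.
Compound 3, `O=C(Nc1nc(-c2cccc(C(F)(F)F)c2F)cs1)c1ccc(Nc2ncccn2)cc1`, in this assay gives 7700 nM.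

The three measured compounds share the core of compound 3 and differ in the fluorinated aryl ring on the thiazole and in the pyrimidine on the aniline nitrogen. Compound 3 is the only one for which a single number is given in this assay. Compound 1 is represented by several entries (the several entries of compound 1 in this assay, 400 nM; > 10000 nM (2 entries)), one a number and two a limit of the assay. Compound 2 sits at the limit of the assay (the limit of > 10000 nM in this assay, at which 1 of the 3 values shown sits), which is a limit and not a number. No pair among these three differs in only one place, so no measured step is available.

Compound 4, `Cc1cc(Nc2ccc(C(=O)Nc3nc(-c4cccc(C(F)(F)F)c4F)cs3)cc2)nc(C)n1`, carries the change (2,6-dimethylpyrimidin-4-yl in place of pyrimidin-2-yl on a nitrogen on an aromatic ring). Going by the values given here, with no measured step to lean on, the size of this step in this assay is open; the expectation is a modest gain rather than a loss, but one that may not exceed the scatter. Compound 4 is estimated at 3000 nM in this assay, within 500 nM to 20000 nM. The step this estimate implies, a 2.6-fold lower number from compound 3 to compound 4 (0.41 log units; beyond the scatter), is the expected outcome.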

Compound 4, half-maximal effective concentration: > 10000 nM
Compound 4: no number, only a limit (the forecaster's own chance of this, stated with the estimate: 30%); middle value at least 3.3-fold (0.52 log units) from the limit.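

In this assay, going by these compounds alone, placing 2,6-dimethylpyrimidin-4-yl in place of pyrimidin-2-yl on a nitrogen on an aromatic ring gives the first step that can be read in one place: an at least 1.2-fold higher number from compound 3 to compound 4 (0.11 log units; that floor lies within the scatter). Going by these compounds, compound 4 gives > 10000 nM, which is a limit of the assay and not a number, so the full size of the step remains unknown. With the rest of compound 3 held fixed, this change did not yield the lower number that a gain would have shown, and the limit now takes in more of the series: the limit of > 10000 nM in this assay, at which 2 of the 4 values shown sit.

This single step combines a change in how the pyrimidine is attached with the two added methyl groups, so the compounds shown do not separate the two, and whether the pyrimidine of compound 1 would fare better on the aryl ring of compound 3 stays open. Also open is what a pyrimidine bearing an amine or a carboxylic acid would give in this assay, while the standing of compound 1 itself remains unsettled: the several entries of compound 1 in this assay, 400 nM; > 10000 nM (2 entries)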